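Swapping the Outer Ring of a Diaryl Ether Amide

A few compounds are considered here, and "the series" means these few. Any claim that something is new, unique, unknown or untested is made for them only; others in the source may bear on it.

Compound 1 `COc1cc(OC)c2c(=O)cc(C(=O)Nc3ccc(N4CCN(C)CC4)cc3)[nH]c2c1` gives > 19800 nM in a functional assay on SEM cells (Homo sapiens) for antiproliferative activity, with a stated time of 72 h (a higher number here means that more compound is needed for the effect, a lower number that less compound is needed), which is a limit of the assay and not a number.
Compound 2 `COc1cc(OC)c2c(=O)cc(C(=O)Nc3ccc(Oc4ccc([N+](=O)[O-])cc4)cc3)[nH]c2c1` gives 480 nM in this assay.
Compound 3 `COc1cc(OC)c2c(=O)cc(C(=O)Nc3ccc(Oc4ccc(F)cc4)cc3)[nH]c2c1` gives > 50000 nM in this assay, again a limit of the assay rather than a number.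

Compound 3 therefore stands only at a limit, and one further value among the three is also a limit; the two limits are the limit of > 19800 nM in this assay, at which 1 of the 3 values shown sits, and (the limit of > 50000 nM in this assay, at which 1 of the 3 values shown sits). Of the measured steps, the closest to the change at hand is an at least 100-fold higher number from compound 2 to compound 3 (2.01 log units; beyond the scatter), a large step. The step that the two limits leave unreadable from compound 1 to compound 3 cannot be read, while an at least 41-fold lower number from compound 1 to compound 2 (1.61 log units; beyond the scatter) shows how far the nitro-bearing ring moves the number.

The change to compound 4 `COc1cc(OC)c2c(=O)cc(C(=O)Nc3ccc(Oc4cccnc4)cc3)[nH]c2c1` is pyridin-3-yl in place of 4-fluorophenyl on an oxygen on an aromatic ring. Among the measured compounds shown here, no measured step carries this exact exchange, and the only numbered neighbour is compound 2, whose ring carries a nitro group instead. With compound 3 at a limit, the direction of an at least 3.3-fold lower number from compound 3 to compound 4 (0.52 log units; beyond the scatter) is expected to be toward a lower number, but its size is uncertain and could still remain at or near a limit. Compound 4 is estimated at 15000 nM, with a plausible range from 1500 nM to 60000 nM.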

Compound 4, half-maximal effective concentration: > 32100 nM
Compound 4: no number, only a limit; the forecaster's own chance of this, stated with the estimate: 45%; middle value at least 2.1-fold (0.33 log units) away from the limit.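

Compound 4 stands at a limit of the assay, not at a number: the limit of > 32100 nM in this assay, at which 1 of the 4 values shown sits.

Exchanging 4-nitrophenyl for pyridin-3-yl on the oxygen gives an at least 66-fold higher number from compound 2 to compound 4 (1.82 log units; beyond the scatter), so a second replacement for the 4-nitrophenyl ring also ends at a limit in this assay. Of the three outer rings shown on this oxygen, only the 4-nitrophenyl ring gives a readable value, and a ring with a hetero atom does not change that. As far as these compounds go, the steps that involve two limits cannot be read, so it remains unknown whether pyridin-3-yl moves the number at all relative to 4-fluorophenyl.

The compounds shown leave open whether the nitro group itself is needed or whether another group at that place on the phenyl ring could serve, such as a nitrile or a carboxylic acid. They also leave open whether a pyridin-3-yl ring carrying a further group, such as an amine, would bring the number down from a limit to a readable value.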